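Side chain changes on the shared core: compound 3

The source may report more compounds than this note shows. Statements on the series, on what has been measured and on what is new or still open speak of the compounds shown alone.

Measured in an ADME assay on MT4 cells (Homo sapiens) for cytotoxicity, read by MTT assay (a lower number here means that less compound is tolerated, a higher number that more compound is tolerated), so far:
- compound 1 (`CCCCCCC1C(=O)N(O)C(=O)c2ccccc21`) gives 4400 nM
- compound 2 (`CC(C)C1C(=O)N(O)C(=O)c2ccccc21`) gives 123000 nM

Compound 1 stands lowest of the two at 4400 nM in this comparison. Compound 3 (`O=C1c2ccccc2C(Cc2ccccc2)C(=O)N1O`) has phenyl in place of pentyl on a saturated chain carbon bound to a saturated ring carbon. Going by the values given here, the one measured step bearing on this is large (a 28-fold higher number from compound 1 to compound 2 (1.45 log units; beyond the scatter)) and has isopropyl in place of hexyl on a saturated ring carbon. The phenyl change itself is unmeasured, so a higher number is expected in this assay. The estimated step, smaller than that one, is expected to be an 8.0-fold higher number from compound 1 to compound 3 (0.90 log units; beyond the scatter). For compound 3 the estimate is 35000 nM (expected range 10000 nM to 120000 nM).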

Compound 3, half-maximal cytotoxic concentration: 95000 nM
The estimate for compound 3 lay 2.7-fold (0.43 log units) below the measured number, within the range that was stated.
By their numbers in this assay, from the lowest: compound 1; then compounds 3 and 2 (each within the scatter of the next).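

In this assay, phenyl in place of pentyl on a saturated chain carbon bound to a saturated ring carbon gives a 22-fold higher number from compound 1 to compound 3 (1.33 log units; beyond the scatter) and so shows a large step from a second, quite different replacement. Going by these compounds alone, compound 3 and compound 2 lie within the scatter of each other, leaving compound 1 with its hexyl as the one low number. No measurement on hand accounts for this step. Open, going by these compounds, is how the number tracks chain length between isopropyl and hexyl, and what a butyl chain, an amine or a carboxylic acid at this place would give.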